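The source may hold more compounds than are shown below. What is called first, only, known or untested is meant among the compounds shown, and "the series" means these compounds.

In a functional assay on HCT-116 cells (Homo sapiens) for antiproliferative activity (a higher number here means a weaker inhibitor, a lower number a stronger inhibitor), three compounds sharing one core have been measured. Compound 1 `Cc1c2c(n3c1CCN(C)C[C@@H](C)[C@H](C)Nc1cc-3ccc1C(N)=O)CC(C)(C)CC2=O`, with methyl on an amine nitrogen in a ring, gives 27 nM. Compound 2 `CC(=O)N1CCc2c(C)c3c(n2-c2ccc(C(N)=O)c(c2)N[C@@H](C)[C@H](C)C1)CC(C)(C)CC3=O`, with acetyl on that nitrogen, gives 24 nM. Compound 3 `COCCC(=O)N1CCc2c(C)c3c(n2-c2ccc(C(N)=O)c(c2)N[C@@H](C)[C@H](C)C1)CC(C)(C)CC3=O`, with (2-methoxyethyl)carbonyl there, gives 38 nM, which lies within the scatter of both other values.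

Compound 4 `CC[C@H](N)C(=O)N1CCc2c(C)c3c(n2-c2ccc(C(N)=O)c(c2)N[C@@H](C)[C@H](C)C1)CC(C)(C)CC3=O` keeps the core and alters one group: 1-aminopropyl in place of 2-methoxyethyl on a carbonyl carbon. In words, 1-aminopropyl stands in place of 2-methoxyethyl on a carbonyl carbon.

The measured changes at this nitrogen bear on that swap. Acetyl for methyl gave a 1.1-fold lower number from compound 1 to compound 2 (0.05 log units; within the scatter), (2-methoxyethyl)carbonyl for methyl gave a 1.4-fold higher number from compound 1 to compound 3 (0.15 log units; within the scatter), and adding methoxymethyl to the acetyl gave a 1.6-fold higher number from compound 2 to compound 3 (0.20 log units; within the scatter). None of these compounds carries 1-aminopropyl, so the new group itself is untested, and the range is kept wide. Nothing beyond the scatter is expected in this assay, and the estimated change is a 1.3-fold lower number from compound 3 to compound 4 (0.10 log units; within the scatter). For compound 4 the expected value is 30 nM, with an estimated range from 12 nM to 75 nM.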

Compound 4, half-maximal inhibitory concentration: 33 nM
Beside the measured number, compound 4's estimate is 1.1-fold (0.04 log units) below it; low and high end bracket the measured number.
By their numbers in this assay, from the lowest: compounds 2, 1, 4 and 3 (each within the scatter of the next).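

In this assay, the place on a carbonyl carbon bound to the amide-type nitrogen in a ring also accepts 1-aminopropyl, which carries a hydrogen-bond donor and a defined stereocentre that 2-methoxyethyl lacks, and the step stays within the scatter (a 1.2-fold lower number from compound 3 to compound 4 (0.06 log units; within the scatter)). The comparisons with the acetyl of compound 2 (a 1.4-fold higher number from compound 2 to compound 4 (0.14 log units; within the scatter)) and the methyl of compound 1 (a 1.2-fold higher number from compound 1 to compound 4 (0.09 log units; within the scatter)) also stay within the scatter, so no step among these four compounds separates the groups. Nothing available explains this result.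

As far as these compounds go, it remains open whether the mirror-image form of 1-aminopropyl, a longer chain ending in an amine, or a carboxylic acid would behave the same way. These compounds also leave open whether any group here can move the number beyond the scatter.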